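The compounds below may be only part of what the source reports. "The series", "measured", "known", "first", "only" and "open" are said of these compounds alone.

Measured so far in an assay on a protein complex for binding affinity to integrin alpha-5/beta-1 (Homo sapiens), read by ELISA, with a stated time of 1 h; a lower number here means a stronger inhibitor, a higher number a weaker inhibitor:
compound 1 `N=C(N)Nc1cccc(C(=O)NCC(=O)N[C@@H](CC(=O)O)C(=O)NCc2ccccc2)c1`: 31 nM
compound 2 `N=C(N)Nc1cccc(C(=O)NCC(=O)N[C@@H](CC(=O)O)C(=O)NC(c2ccccc2)c2ccccc2)c1`: 22 nM

Compound 1 holds the higher of the two numbers shown, yet the gap to compound 2 is a 1.4-fold lower number from compound 1 to compound 2 (0.15 log units; within the scatter), within the scatter. Compound 3 `C[C@@H](NC(=O)[C@H](CC(=O)O)NC(=O)CNC(=O)c1cccc(NC(=N)N)c1)c1ccccc1` differs from compound 1 by methyl in place of hydrogen on a saturated chain carbon bound to an amide-type nitrogen and an aromatic carbon. Among the compounds with values here, the only measured step that bears on this position is the one from compound 1 to compound 2, which added phenyl at the same carbon and moved a 1.4-fold lower number from compound 1 to compound 2 (0.15 log units; within the scatter). A smaller group added there is therefore expected to give no shift beyond the scatter in this assay. The estimate for compound 3 is 28 nM, between 12 nM and 70 nM, meaning an expected step of a 1.1-fold lower number from compound 1 to compound 3 (0.04 log units; within the scatter).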

Compound 3, half-maximal inhibitory concentration: 45 nM
Compound 3: the middle estimate sits 1.6-fold (0.21 log units) below what was measured; the measured number falls inside the stated range.
By their numbers in this assay, from the lowest: compounds 2, 1 and 3 (each within the scatter of the next, the first and the last beyond it).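

In this assay, methyl on the saturated chain carbon bound to an amide-type nitrogen and an aromatic carbon gives a 1.5-fold higher number from compound 1 to compound 3 (0.16 log units; within the scatter). Together with a 1.4-fold lower number from compound 1 to compound 2 (0.15 log units; within the scatter), this shows that two different groups at this carbon, methyl and phenyl, each leave the number within the scatter of compound 1, so no trend across the groups can be read. No evidence is available to explain this result. As far as these compounds go, it remains open whether a carboxylic acid, an amine or an ethyl group on this carbon would also stay within the scatter of compound 1.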